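Compound 2 gains a nitro group

The source may hold more compounds than are shown below. What is called first, only, known or untested is meant among the compounds shown, and "the series" means these compounds.

In a functional assay on OVCAR-3 cells (Homo sapiens) for inhibition, read by sulforhodamine B assay, with a stated time of 48 h (on this read-out lower numbers stand for stronger inhibition of growth and higher numbers for weaker inhibition of growth), compound 1 (`CC(C)(C)NCc1c(C(=O)O)nn(-c2ccc(Cl)cc2)c1-c1ccc(F)cc1`) gives 116000 nM and compound 2 (`CC(C)(C)NCc1c(C(=O)O)nn(-c2ccc(Cl)cc2)c1-c1ccccc1`) gives 653000 nM, the higher of the two numbers. Compound 3 (`CC(C)(C)NCc1c(C(=O)O)nn(-c2ccc(Cl)cc2)c1-c1ccc([N+](=O)[O-])cc1`) turns the phenyl of compound 2 into 4-nitrophenyl, with nitro in place of hydrogen on an aromatic carbon, para to a large group: nitro in place of hydrogen on an aromatic carbon. Among the compounds with values here, only one measured step bears on this change. It is hydrogen in place of fluoro on an aromatic carbon, and it gives a 5.6-fold higher number from compound 1 to compound 2 (0.75 log units; beyond the scatter). Nitro is not fluoro, so this single step offers only loose guidance. Going by a 5.6-fold higher number from compound 1 to compound 2 (0.75 log units; beyond the scatter), a modest step to a lower number is expected, though a result within the scatter cannot be ruled out. The expected change is a 3.0-fold lower number from compound 2 to compound 3 (0.47 log units; beyond the scatter). For compound 3 the estimated value is 220000 nM, with an expected range of 60000 nM to 650000 nM.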

Compound 3, concentration for 50% growth inhibition: 162000 nM
Estimate against measurement, compound 3: 1.4-fold (0.13 log units) above; the range from low to high includes it.
By their numbers in this assay, from the lowest: compounds 1 and 3 (each within the scatter of the next); then compound 2.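

In this assay the place on the aromatic carbon para to a large group now has two substituents in place of hydrogen, and nitro, like fluoro before it, goes with a lower number, giving a 4.0-fold lower number from compound 2 to compound 3 (0.61 log units; beyond the scatter). Fluoro and nitro cannot be told apart at this place, with a 1.4-fold higher number from compound 1 to compound 3 (0.15 log units; within the scatter), so among these three compounds the line falls between hydrogen and either substituent rather than between the two substituents. No measurement shown here explains this result.

On these data alone, whether a methoxy group, a nitrile or a longer chain at this same place would also read like fluoro and nitro remains open. So does whether the same changes would carry over if the rest of the shared core were altered.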